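The compounds below may be only part of what the source reports. "The series", "measured", "known", "first", "only" and "open" are said of these compounds alone.

Compound 1 `CNc1nnc(-c2cn3ncnc(Nc4cc(C(=O)NC5CC5)c(F)cc4F)c3c2C(C)C)o1`, compound 2 `CCCNc1nnc(-c2cn3ncnc(Nc4cc(C(=O)NC5CC5)c(F)cc4F)c3c2C(C)C)o1` and compound 3 `CC(C)c1c(-c2nnc(NCCO)o2)cn2ncnc(Nc3cc(C(=O)NC4CC4)c(F)cc3F)c12` share one core and differ only in a single side chain. In a functional assay on HUVEC cells (Homo sapiens) for antiproliferative activity (a lower number here means a stronger inhibitor, a higher number a weaker inhibitor), compound 1 has the entry "not determined" (no result reported), and compound 2 has the entry "not determined" (no result reported). Within the data shown here, that leaves compound 3, at 140 nM, as the only number available, so it cannot yet be ranked against anything.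

Compound 4 `CC(C)c1c(-c2nnc(OCC3CCNCC3)o2)cn2ncnc(Nc3cc(C(=O)NC4CC4)c(F)cc3F)c12` has not yet been measured. Its structure departs from compound 3 as follows: (piperidin-4-yl)methoxy in place of (2-hydroxyethyl)amino on an aromatic carbon. In words, (piperidin-4-yl)methoxy stands in place of (2-hydroxyethyl)amino on an aromatic carbon.

Among the measured compounds shown here, no measured pair of compounds shows what such a swap does in this assay, so the data offer no direction. The expectation is therefore no step beyond the usual scatter, either way. This rests on a single reference point, compound 3 at 140 nM, so the range is kept wide. The estimated step is a 1.2-fold lower number from compound 3 to compound 4 (0.07 log units; within the scatter). For compound 4, the expected value is 120 nM, with an estimated range of 35 nM to 400 nM.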

Compound 4, half-maximal inhibitory concentration: 25 nM
For compound 4 the middle estimate is 4.8-fold (0.68 log units) above the measured one; measured number outside the range, below it.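

The swap brings a 5.6-fold lower number from compound 3 to compound 4 (0.75 log units; beyond the scatter) in this assay and so shows that the side chain on this aromatic carbon of the five-membered aromatic ring does affect the result. It also shows that this position accepts a larger group containing a six-membered non-aromatic ring, with the number going down rather than up. No measured property is available to explain this step.

The swap replaces both the linking atom and the rest of the chain, so the two compounds cannot show which of these changes matters. A (piperidin-4-yl)methylamino group, which would keep the ring but link it through an amine, or a 2-hydroxyethoxy chain, which would keep the hydroxyethyl end but link it through oxygen, would separate the two effects.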